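The source may report more compounds than this note shows. Statements on the series, on what has been measured and on what is new or still open speak of the compounds shown alone.

In a functional assay on DU-145 cells (Homo sapiens) for inhibition, read by trypan blue exclusion, with a stated time of 72 h (on this read-out higher numbers stand for weaker inhibition and lower numbers for stronger inhibition), compound 2 `O=c1c(S(=O)(=O)c2ccc(F)cc2F)cc2cnc(Nc3ccc4[nH]ccc4c3)nc2n1CC1CC1` gives 1000 nM. Among the compounds with values here, that is the lower of the two numbers measured so far; compound 1 `COC(=O)Cn1ccc2cc(Nc3ncc4cc(S(=O)(=O)c5ccc(F)cc5F)c(=O)n(C)c4n3)ccc21` gives 5000 nM, and the gap between them lies beyond the scatter. Compound 3 `COC(=O)Cn1c(=O)c(S(=O)(=O)c2ccc(F)cc2F)cc2cnc(Nc3ccc4[nH]ccc4c3)nc21` has not yet been measured. It differs from compound 2 in one place: methoxycarbonyl in place of cyclopropyl on a saturated chain carbon bound to an aromatic nitrogen. Within the data shown here, no measured pair shows this change alone, and compound 1 differs from compound 3 in more than one place, so its value gives no direct guide. The author expects a modest weakening in this assay, a 2.5-fold higher number from compound 2 to compound 3 (0.40 log units; beyond the scatter). Compound 3 is therefore estimated at 2500 nM, within a range from 700 nM to 9000 nM.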

Compound 3, half-maximal inhibitory concentration: 10000 nM
Beside the measured number, compound 3's estimate is 4.0-fold (0.60 log units) below it; the whole stated range lies below it.
By their numbers in this assay, from the lowest: compound 2; then compounds 1 and 3 (each within the scatter of the next).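

In this assay, a 10-fold higher number from compound 2 to compound 3 (1.00 log units; beyond the scatter) on a saturated chain carbon bound to an aromatic nitrogen. Within the data shown here, this is the first single-place comparison, and it shows that this position is sensitive to the exchange of cyclopropyl for methoxycarbonyl. Nothing available here accounts for the size of the step. The compounds shown leave open whether the step follows from gaining methoxycarbonyl or from losing cyclopropyl. They also leave open how a carboxylic acid, an amine or a longer chain would read at this place.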